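A few compounds are considered here, and "the series" means these few. Any claim that something is new, unique, unknown or untested is made for them only; others in the source may bear on it.

In a functional assay on HCT-116 cells (Homo sapiens) for antiproliferative activity, with a stated time of 72 h (a higher number here means a weaker inhibitor, a lower number a stronger inhibitor), compound 1 `CCCCC#Cc1cc([C@@H]2O[C@H](CO)[C@@H](O)[C@H]2O)n2ncnc(N)c12` gives 2900 nM, compound 2 `Nc1ncnn2c([C@@H]3O[C@H](CO)[C@@H](O)[C@H]3O)cc(-c3ccc(F)cc3)c12` gives 42500 nM and compound 3 `Nc1ncnn2c([C@@H]3O[C@H](CO)[C@@H](O)[C@H]3O)cc(-c3ccoc3)c12` gives 1400 nM, the lowest of the three numbers. Within the data shown here, compound 4 `Nc1ncnn2c([C@@H]3O[C@H](CO)[C@@H](O)[C@H]3O)cc(-c3ccsc3)c12` changes only one group of compound 3: thiophen-3-yl in place of furan-3-yl on an aromatic carbon. Changes at this carbon can matter: the steps are a 15-fold higher number from compound 1 to compound 2 (1.17 log units; beyond the scatter) and a 30-fold lower number from compound 2 to compound 3 (1.48 log units; beyond the scatter), both large, and a 2.1-fold lower number from compound 1 to compound 3 (0.32 log units; beyond the scatter), modest. None of these exchanges one five-membered aromatic ring for another, so they bear only indirectly on this swap. The close match in the counted features points to little change, and no step beyond the scatter is expected in this assay, with a 1.1-fold higher number from compound 3 to compound 4 (0.03 log units; within the scatter) as the estimate. Compound 4 is expected at 1500 nM, within an estimated range of 500 nM to 5000 nM.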

Compound 4, half-maximal inhibitory concentration: 45200 nM
Estimate against measurement, compound 4: 30-fold (1.48 log units) below, outside the stated range (above it).
By their numbers in this assay, from the lowest: compound 3; then compound 1; then compounds 2 and 4 (each within the scatter of the next).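

In this assay, furan-3-yl and thiophen-3-yl are not interchangeable on this aromatic carbon, despite their matching counted features (a 32-fold higher number from compound 3 to compound 4 (1.51 log units; beyond the scatter)). Thiophen-3-yl stands with 4-fluorophenyl and not with furan-3-yl (a 1.1-fold higher number from compound 2 to compound 4 (0.03 log units; within the scatter)), and it also falls well short of hex-1-yn-1-yl (a 16-fold higher number from compound 1 to compound 4 (1.19 log units; beyond the scatter)), so sharing a five-membered aromatic ring with one hetero atom does not place compound 3 and compound 4 together. No available measurement explains the gap between oxygen and sulfur in this ring. On these data alone, whether an amine or a carboxylic acid on this carbon would keep the number of compound 3 remains open.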